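The source may hold more compounds than are shown below. What is called first, only, known or untested is meant among the compounds shown, and "the series" means these compounds.

Compound 1 `CC(C)=CCC/C(C)=C/CC/C(C)=C/CSC[C@H](NC(=O)CCCCCN1CCN(C)CC1)C(=O)NC1CCCCCC1`: 2700 nM
Compound 2 `CC(C)=CCC/C(C)=C/CC/C(C)=C/CSC[C@H](NC(=O)CCCCCN1CCCC1)C(=O)NC1CCCCC1`: 5600 nM
Compound 3 `CC(C)=CCC/C(C)=C/CC/C(C)=C/CSc1ccccc1C(N)=O`: > 20000 nM

These three compounds were tested in a functional assay on MIA PaCa-2 cells (Homo sapiens) for cytotoxicity, read by fluorescence, with a stated time of 48 h; a higher number here means that more compound is needed for the effect, a lower number that less compound is needed. Only two of them gave an exact number, and compound 2 has the higher of the two at 5600 nM. Its gap to compound 1 lies beyond the scatter, so compound 2 needs more compound for the same effect. Compound 3 gave no exact number, only a limit of the assay, > 20000 nM.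

Compound 4 `CC(C)=CCC/C(C)=C/CC/C(C)=C/CSC[C@H](NC(=O)CCCCCN1CCCC1)C(=O)NC1CC1` has not yet been measured. It keeps the rest of compound 2 and makes one change: cyclopropyl in place of cyclohexyl on an amide-type nitrogen.

Within the data shown here, no measured pair isolates this change, so any expectation is loose. The expected move is a 1.8-fold higher number from compound 2 to compound 4 (0.25 log units; within the scatter), a modest step toward a higher number in this assay, though it may not clear the scatter by much. Compound 4 is estimated at 10000 nM, with an expected range of 4500 nM to 20000 nM.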

Compound 4, half-maximal effective concentration: > 20000 nM
Compound 4: a limit, no number; the forecaster's own chance of this, stated with the estimate: 20%; at least 2.0-fold (0.30 log units) between middle value and limit.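

In this assay, putting cyclopropyl in place of cyclohexyl on an amide-type nitrogen gives an at least 3.5-fold higher number from compound 2 to compound 4 (0.55 log units; beyond the scatter). Among these compounds, this is the only comparison here that changes one place, and it shows that the group on this nitrogen matters: with the rest of compound 2 kept, going from 6 heavy atoms in the ring to 3 means more compound is needed for the effect. Compound 4 gives a limit of the assay rather than a number, and the full size of the step stays unknown because of that limit: the limit of > 20000 nM in this assay, at which 2 of the 4 values shown sit.

The compounds shown leave open how the number changes for ring sizes between these two, such as cyclopentyl. They also leave open whether an open chain such as n-butyl, or an aromatic phenyl ring, on this nitrogen would match cyclohexyl.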